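Methoxy in place of chloro on the shared core

The source may hold more compounds than are shown below. What is called first, only, known or untested is meant among the compounds shown, and "the series" means these compounds.

Compound 1 `CCOc1ccc2nc(Cl)c(/C=C3\SC(=S)NC3=O)cc2c1` and compound 2 `O=C1NC(=S)S/C1=C\c1cc2cc(Cl)ccc2nc1Cl` share one core and differ only in a single aromatic substituent. In a toxicity assay on A549 cells (Homo sapiens) for cytotoxicity, read by MTT assay, with a stated time of 48 h (a higher number here means a weaker inhibitor of growth, a lower number a stronger inhibitor of growth), compound 1 gives > 100 ug/mL, which is a limit of the assay and not a number. In this assay compound 2 likewise gives > 100 ug/mL, again a limit of the assay. The step that the two limits leave unreadable from compound 1 to compound 2 therefore cannot be read in size. Among the measured compounds shown here, the one piece of evidence is the limit of > 100 ug/mL in this assay, at which 2 of the 2 values shown sit. Compound 2 thus stands at that limit, alongside compound 1, with no readable number of its own.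

Compound 3 `COc1ccc2nc(Cl)c(/C=C3\SC(=S)NC3=O)cc2c1` differs from compound 2 by methoxy in place of chloro on an aromatic carbon. For the measured compounds named here, the only measured step, from compound 1 to compound 2, concerns the same aromatic carbon, but it sits between two limits and gives no size; compound 1 carries ethoxy at that carbon, compound 3 methoxy. Going by the values given here, no measured step in this assay shows movement beyond the scatter, so no shift beyond the scatter is expected, and the expected step that the limit leaves unreadable from compound 2 to compound 3 is sized accordingly. Compound 3 is expected to give 150 ug/mL in this assay, within a range from 60 ug/mL to 500 ug/mL, most probably reported once more only as a limit.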

Compound 3, concentration for 50% growth inhibition: > 100 ug/mL
Compound 3: no number, only a limit; the forecaster's own chance of this, stated with the estimate: 85%; the middle value is on the limit's open side.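

In this assay compound 3 gives > 100 ug/mL, a limit of the assay and not a number. Among the compounds shown here, no step among compound 1, compound 2 and compound 3 can therefore be read in size. The compounds shown leave open how ethoxy, methoxy and chloro on that aromatic carbon compare in growth inhibition, with every value at one limit: the limit of > 100 ug/mL in this assay, at which 3 of the 3 values shown sit.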